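Trimethoxyphenyl substitution on the five-membered ring of the chalcone series

A few compounds are considered here, and "the series" means these few. Any claim that something is new, unique, unknown or untested is made for them only; others in the source may bear on it.

Three members of this series have been characterised in a functional assay on SNB-75 cells (Homo sapiens) for inhibition (a lower number here means a stronger inhibitor of growth, a higher number a weaker inhibitor of growth), so far. Compound 1 `COc1cc(/C=C/C(=O)c2cccc(-n3cc(-c4ccc(Cl)cc4)[nH]c3=O)c2)cc(OC)c1OC` is recorded there as "not active" (no number reported), with no number given. Compound 2 `COc1cc(/C=C/C(=O)c2cccc(-n3cc(-c4ccccc4)[nH]c3=O)c2)cc(OC)c1OC` gives 4470 nM in this assay, and compound 3 `COc1ccc(-c2cn(-c3cccc(C(=O)/C=C/c4cc(OC)c(OC)c(OC)c4)c3)c(=O)[nH]2)cc1` gives 4590 nM. On the numbers shown, compound 3 sits together with compound 2: the single measured step, a 1.0-fold higher number from compound 2 to compound 3 (0.01 log units; within the scatter), falls within the scatter, so the two cannot be told apart, and compound 1 contributes no number to place beside them.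

Compound 4 `COc1cc(/C=C/C(=O)c2cccc(-n3cc(-c4cc(OC)c(OC)c(OC)c4)[nH]c3=O)c2)cc(OC)c1OC` is the next member, not yet measured. It differs from compound 3 in one place: 3,4,5-trimethoxyphenyl in place of 4-methoxyphenyl on an aromatic carbon. Going by the values given here, the one step that bears on this change is the methoxy addition from compound 2 to compound 3, which produced no shift beyond the scatter. Among the compounds with values here, compound 4 adds further methoxy groups at the same position, and there is no measured step that shows what such additions do beyond the first. The expectation for compound 4 in this assay is therefore no step beyond the scatter, estimated as a 1.0-fold lower number from compound 3 to compound 4 (0.01 log units; within the scatter). Compound 4 is thus expected to give about 4500 nM, with a range from 2000 nM to 10000 nM; the outcome of compound 1 is a reminder that the assay may also return no number.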

Compound 4, concentration for 50% growth inhibition: 5130 nM
For compound 4 the middle estimate is 1.1-fold (0.06 log units) below the measured one, and the stated range covers the measured number.
By their numbers in this assay, from the lowest: compounds 2, 3 and 4 (each within the scatter of the next).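

In this assay, the position on the five-membered aromatic ring, two ring bonds from the ring nitrogen, now tolerates 3,4,5-trimethoxyphenyl as well as the smaller groups: a 1.1-fold higher number from compound 3 to compound 4 (0.05 log units; within the scatter), and a 1.1-fold higher number from compound 2 to compound 4 (0.06 log units; within the scatter). The earlier compounds shown here covered only the single methoxy of 4-methoxyphenyl, whereas compounds 2, 3 and 4 now show that phenyl, 4-methoxyphenyl and 3,4,5-trimethoxyphenyl cannot be told apart at this position, with compound 1, which carries 4-chlorophenyl and reads "not active" (no number reported), standing against any wider claim for aryl groups here. No measurement at hand accounts for this flat reading or for the result of compound 1.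

Still open, from the compounds shown here alone, is whether any group at this position moves the number beyond the scatter in this assay, for example an amine or a carboxylic acid on the phenyl ring, or a longer alkyl chain in place of that ring. The compounds shown also leave unsettled whether the reading of compound 1 belongs to chlorine alone or would recur with fluorine or bromine at the same place on the phenyl ring.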